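Compound 4: an expected step within the scatter

The source may hold more compounds than are shown below. What is called first, only, known or untested is meant among the compounds shown, and "the series" means these compounds.

In a functional assay on MCF7 cells (Homo sapiens) for cytotoxicity, read by MTT assay, with a stated time of 72 h (a higher number here means a weaker inhibitor, a lower number a stronger inhibitor), compound 3 `COc1cccc(C=C2C(=O)N(c3ccc(Cl)cc3)N(c3ccc(Cl)cc3)C2=O)c1` gives 18100 nM, within the scatter of compound 2 `O=C1C(=Cc2ccc(O)cc2)C(=O)N(c2ccc(Cl)cc2)N1c1ccc(Cl)cc1` at 23200 nM. Compound 1 `CCC(C)=C1C(=O)N(c2ccc(Cl)cc2)N(c2ccc(Cl)cc2)C1=O` gives 41600 nM, a higher number than that of compound 3, and this gap lies beyond the scatter. Compound 4 `O=C1C(=Cc2c[nH]c3ccccc23)C(=O)N(c2ccc(Cl)cc2)N1c1ccc(Cl)cc1` carries 1H-indol-3-yl in place of 3-methoxyphenyl on a double-bonded chain carbon bound to a double-bonded ring carbon. Within the data shown here, the only measured step at this place, a 1.3-fold lower number from compound 2 to compound 3 (0.11 log units; within the scatter), exchanged 4-hydroxyphenyl for 3-methoxyphenyl and stayed within the scatter. A single step is thin evidence, but no change beyond the scatter is expected in this assay. The expected step is a 1.1-fold lower number from compound 3 to compound 4 (0.05 log units; within the scatter). For compound 4 the estimate is 16000 nM, with an expected range from 7000 nM to 35000 nM.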

Compound 4, half-maximal inhibitory concentration: 34200 nM
Compound 4: middle estimate off by 2.1-fold (0.33 log units), on the low side; the range from low to high includes it.
By their numbers in this assay, from the lowest: compounds 3, 2, 4 and 1 (each within the scatter of the next, the first and the last beyond it).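

In this assay, 1H-indol-3-yl on a double-bonded chain carbon bound to a double-bonded ring carbon gives a 1.9-fold higher number from compound 3 to compound 4 (0.28 log units; within the scatter) and a 1.5-fold higher number from compound 2 to compound 4 (0.17 log units; within the scatter), so both steps stay within the scatter. The three aromatic groups at this place in compounds 2, 3 and 4, one of them holding a five-membered aromatic ring with a nitrogen, are thus not told apart by this read-out. Nothing shown gives a reason for these values. From the compounds shown here alone, whether an amine or a carboxylic acid at this place would give a step beyond the scatter stays open.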